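Swapping a hydroxy for chloro on the phenylpiperazine ring

This account rests on a few compounds, and the source may have more. Where it says the series, first, only, none or still open, it means among the compounds named here.

Compound 1 `COC(=O)C1=C(C)NC(=O)N(C(=O)NCCCN2CCN(c3ccccc3O)CC2)C1c1ccc(F)c(F)c1` is one of two close relatives tested in an assay on liver for binding affinity to Alpha-1B adrenergic receptor (Homo sapiens), using microsomes; a lower number here means a stronger inhibitor, a higher number a weaker inhibitor. In this assay compound 1 gives 16 nM, the highest of the two numbers seen so far. Its nearest neighbour is compound 2 `COC(=O)C1=C(C)NC(=O)N(C(=O)NCCCN2CCN(c3cccc(Cl)c3)CC2)C1c1ccc(F)c(F)c1`, which in this assay gives 8.4 nM; the shift a 1.9-fold lower number from compound 1 to compound 2 (0.28 log units; within the scatter) is too small to count as a real change.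

Compound 3 `COC(=O)C1=C(C)NC(=O)N(C(=O)NCCCN2CCN(c3ccccc3Cl)CC2)C1c1ccc(F)c(F)c1` has not been measured. It differs from compound 1 by chloro in place of hydroxy on an aromatic carbon, a chloro in place of hydroxy on an aromatic carbon, here sitting ortho to a large group on the ring attached to the amine nitrogen. For the measured compounds named here, the only measured step that bears on this is the one from compound 1 to compound 2, where chloro also replaced hydroxy on the same ring, though at a different position, and the number moved only within the scatter. Going by the values given here, no measured pair shows what a chloro at this exact position does.

The expectation for compound 3 is therefore a step of about a 1.5-fold lower number from compound 1 to compound 3 (0.16 log units; within the scatter), not clearly beyond the scatter, leaning slightly toward a lower number. The estimated value for compound 3 in this assay is 11 nM, with a range from 4 nM to 30 nM.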

Compound 3, inhibition constant: 15 nM
Compound 3: the middle estimate sits 1.4-fold (0.13 log units) below what was measured; the measured number falls inside the stated range.
By their numbers in this assay, from the lowest: compounds 2, 3 and 1 (each within the scatter of the next).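

In this assay the exchange of hydroxy for chloro on the aromatic carbon ortho to a large group gives a 1.1-fold lower number from compound 1 to compound 3 (0.03 log units; within the scatter) so at this place the number holds even though the hydrogen-bond donor and acceptor counted for hydroxy are gone. The earlier pair showed the same kind of exchange only with the chloro elsewhere on the ring, and the new comparison of the two chloro compounds, with 2-chlorophenyl in place of 3-chlorophenyl, gives a 1.8-fold higher number from compound 2 to compound 3 (0.25 log units; within the scatter) so these two placings of chloro cannot be told apart in this assay. Nothing further is available to explain why the number stays put across these changes.

Going by these compounds, all three compounds lie within the scatter of one another, so it remains open whether any change on this ring can move the number by a clear margin. A methoxy group, an amine or a carboxylic acid at this same place, or a plain phenyl ring with no group at all, would test how far this tolerance extends.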